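The source may hold more compounds than are shown below. What is called first, only, known or untested is meant among the compounds shown, and "the series" means these compounds.

Among the measured compounds shown here, compound 2 `CC(=O)c1ccc(OCCCN2CC[C@H](NC(=O)[C@@H](N)CO)C2)cc1` stands at the weaker end of the two numbers measured so far in an assay on isolated protein for binding affinity to histamine H2 receptor (Homo sapiens) (a higher number here means a weaker inhibitor, a lower number a stronger inhibitor), where compound 2 gives 22000 nM. For the measured compounds named here, its only neighbour is compound 1 `CC(=O)c1ccc(OCCCN2CC[C@H](NC(=O)c3ccc(C#N)cc3)C2)cc1`, which in this assay gives 6100 nM; the step of a 3.6-fold higher number from compound 1 to compound 2 (0.56 log units; beyond the scatter) exchanged an aromatic ring on the carbonyl carbon for a group with no ring. Compound 3 `CC(=O)c1ccc(OCCCN2CC[C@H](NC(=O)c3cccnc3)C2)cc1` reverses that kind of exchange: pyridin-3-yl in place of 1-amino-2-hydroxyethyl on a carbonyl carbon. Going by the values given here, only the step from compound 1 to compound 2 bears on the question, and it moved to a higher number when the ring was removed; bringing back a six-membered aromatic ring is therefore expected to move the number back down, roughly to where compound 1 sits, though the ring now carries a hetero atom and differs from the one in compound 1. Compound 3 is expected to give 7000 nM in this assay, within 2500 nM to 20000 nM. That estimate means a step of a 3.1-fold lower number from compound 2 to compound 3 (0.50 log units; beyond the scatter).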

Compound 3, inhibition constant: 3500 nM
Compound 3: middle estimate off by 2.0-fold (0.30 log units), on the high side, within the range that was stated.
By their numbers in this assay, from the lowest: compounds 3 and 1 (each within the scatter of the next); then compound 2.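

With pyridin-3-yl in place of 1-amino-2-hydroxyethyl on the carbonyl carbon, this assay records a 6.3-fold lower number from compound 2 to compound 3 (0.80 log units; beyond the scatter), so the change seen on leaving an aromatic ring at this position can be undone with a different ring. The two rings are not told apart, with a 1.7-fold lower number from compound 1 to compound 3 (0.24 log units; within the scatter), which means that in these three compounds neither the nitrile of 4-cyanophenyl nor the hetero atom of pyridin-3-yl separates the ring-bearing compounds. The evidence at hand offers no explanation for these differences.

On these data alone, the step from compound 2 changes the ring, the amino group and the hydroxyl group together, so it remains open which of these goes with the higher number of compound 2. A cyclohexyl ring or an unsubstituted phenyl ring on the same carbonyl carbon would help to separate these features.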